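The source may report more compounds than this note shows. Statements on the series, on what has been measured and on what is new or still open speak of the compounds shown alone.

Working notes on the series. Two compounds have been run in a functional assay, read by spectrophotometry, with a stated time of 15 min, tested at 20 ug/mL (on this read-out lower numbers stand for a weaker effect and higher numbers for a stronger effect at the one concentration tested), so far. Compound 1 `COC(=O)c1cc(-c2csc(N/N=C/c3cccs3)n2)ccc1OCc1ccccc1` gives 79.6% in this assay. Compound 2 `Fc1ccc(-c2csc(N/N=C/c3ccc(Cl)cc3Cl)n2)cc1` gives 88.4% in this assay. For the measured compounds named here, of the two numbers in hand, the one for compound 1 is the lower, but its gap to compound 2 lies within the usual scatter of repeat runs, so no order between the two is claimed.

Compound 3 `COC(=O)c1cc(-c2csc(N/N=C/c3ccc(Cl)cc3Cl)n2)ccc1OCc1ccccc1` has not yet been run in this assay. Against compound 1 it differs in one place: 2,4-dichlorophenyl in place of thiophen-2-yl on a carbon with a double bond to nitrogen. Going by the values given here, no pair of measured compounds differs by a single change, so no step of this kind has been seen yet and there is no measured step to lean on.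

The expectation is that the step in this assay will be small, a number 4.4 percentage points higher from compound 1 to compound 3 (within the scatter), with no direction beyond the scatter asserted. Among the compounds with values here, compound 3 is estimated at 84% in this assay, within a range of 70% to 95%, because compound 1 already gives 79.6% and the only other number, for compound 2, sits near it.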

Compound 3, a percentage reported as inhibition, at one concentration (the size of the read-out at that concentration, not a potency): 58.9%
For compound 3 the middle estimate is 25.1 percentage points above the measured one; the measured number lies below the stated range.
By their numbers in this assay, from the lowest: compound 3; then compounds 1 and 2 (each within the scatter of the next).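

In this assay, this position gives the first single-change read-out in the series: 2,4-dichlorophenyl in place of thiophen-2-yl on a carbon with a double bond to nitrogen gives a number 20.7 percentage points lower from compound 1 to compound 3 (beyond the scatter). On the core of compound 1, then, the two aromatic groups at this position are not interchangeable. The 2,4-dichlorophenyl group does not by itself go with a low number, since compound 2 carries it on a different remainder and gives 88.4%, so the step holds only for the core of compound 1. No measurement at hand offers a reason for the drop.

This single step cannot separate the change of ring from the presence of the two chlorine atoms, and the compounds shown do not tell how plain phenyl, 4-chlorophenyl or furan-2-yl would read at this position. Also open, going by these compounds, is whether thiophen-2-yl would give a similar step on the remainder of compound 2, and whether a ring bearing an amine or a carboxylic acid would be accepted here.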